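Tetrahydroisoquinoline in place of tert-butoxy: expected solubility

The source may report more compounds than this note shows. Statements on the series, on what has been measured and on what is new or still open speak of the compounds shown alone.

Measured so far:
compound 1, `COc1cccc(CN2C(=O)CN(C(=O)c3cc4cc(OC)ccc4[nH]3)C[C@@H]2CCc2ccccc2)c1`, 5100 nM
compound 2, `COc1ccc2[nH]c(C(=O)N3CC(=O)N(Cc4ccccc4)[C@@H](COC(C)(C)C)C3)cc2c1`, 65500 nM
compound 3, `COc1ccc2[nH]c(C(=O)N3CC(=O)N(Cc4cccc(OC(F)F)c4)[C@@H](CN4CCC(c5ccccn5)CC4)C3)cc2c1`, 11600 nM

In a physicochemical assay for solubility, read by spectrophotometry, in phosphate buffer, with a stated time of 2 h, at pH 7.4 (on this read-out lower numbers stand for lower solubility and higher numbers for higher solubility), compound 2 stands highest of the three numbers, with compound 3 nearest and compound 1 furthest, both beyond the scatter. Compound 4, `COc1ccc2[nH]c(C(=O)N3CC(=O)N(Cc4ccccc4)[C@@H](CN4CCc5ccccc5C4)C3)cc2c1`, has not yet been measured in this assay. It differs from compound 2 in one place: 1,2,3,4-tetrahydroisoquinolin-2-yl in place of tert-butoxy on a saturated chain carbon bound to a saturated ring carbon. For the measured compounds named here, no step between measured compounds isolates this change, so the expectation rests on the spread of the three numbers. Compound 4 is expected to lie below compound 2, with a step of a 4.4-fold lower number from compound 2 to compound 4 (0.64 log units; beyond the scatter) beyond the scatter. Compound 4 is estimated at 15000 nM, between 4000 nM and 50000 nM.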

Compound 4, solubility: 9000 nM
Compound 4: middle estimate off by 1.7-fold (0.22 log units), on the high side; low and high end bracket the measured number.
By their numbers in this assay, from the lowest: compounds 1, 4 and 3 (each within the scatter of the next, the first and the last beyond it); then compound 2.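

In this assay this position now has its first comparison that differs in one place: 1,2,3,4-tetrahydroisoquinolin-2-yl in place of tert-butoxy gives a 7.3-fold lower number from compound 2 to compound 4 (0.86 log units; beyond the scatter), a step beyond the scatter. The earlier compounds shown here differed in more than one place and could not isolate this change at the saturated chain carbon bound to a saturated ring carbon. Nothing measured here accounts for the step. The compounds shown leave open how a morpholine or a carboxylic acid would read at this place, and whether the step holds with other groups on the benzyl ring.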